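The source may report more compounds than this note shows. Statements on the series, on what has been measured and on what is new or still open speak of the compounds shown alone.

Three compounds have been measured in an assay on BTI cells for inhibition of Amine oxidase [flavin-containing] B (Homo sapiens), read by fluorescence, with stated times of 30 min and 1 h, tested at 1 uM; on this read-out higher numbers stand for more inhibition at the one concentration tested (going by the name of the read-out) and lower numbers for less inhibition:

Compound 1, `C#CCNC1CCc2c(OCCCCCN3CCN(c4cccc5c4ccn5Cc4cccc(Cl)c4)CC3)cccc21`, gives 80%.
Compound 2, `C#CCNC1CCc2c(OCCCCCN3CCN(c4cccc5c4ccn5S(=O)(=O)c4ccccc4)CC3)cccc21`, gives 90%.
Compound 3, `C[C@H](NCc1ccc(OCCCCCN2CCN(c3cccc4c3ccn4Cc3cccc(Cl)c3)CC2)cc1)C(N)=O`, gives 43%.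

Compound 1 and compound 2 share one core and differ in a single place: phenylsulfonyl in place of 3-chlorobenzyl on an aromatic nitrogen. This change gives a number 10 percentage points higher from compound 1 to compound 2 (within the scatter), so the two readings cannot be told apart by this kind of measurement. Compound 3 is built on a different core; the difference between the core of compound 3 and the core of compound 1 is not broken down here. Compound 3 stands lowest of the three, and its distance to compound 1 as well as to compound 2 lies beyond the scatter.

Compound 4, `C[C@H](NCc1ccc(OCCCCCN2CCN(c3cccc4c3ccn4S(=O)(=O)c3ccccc3)CC2)cc1)C(N)=O`, has not yet been measured. It differs from compound 3 in one place: phenylsulfonyl in place of 3-chlorobenzyl on an aromatic nitrogen. Within the data shown here, this is the same change that leads from compound 1 to compound 2, made at a place that is described in the same words, so the one earlier step is the only guide. Because that earlier step was a number 10 percentage points higher from compound 1 to compound 2 (within the scatter), the step from compound 3 to compound 4 is expected to be small as well, about a number 7 percentage points higher from compound 3 to compound 4 (within the scatter). Among the measured compounds shown here, compound 4 is therefore estimated at 50% in this assay, with a likely range from 30% to 70%, resting on the single value of compound 3, 43%, and the one earlier step.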

Compound 4, a percentage reported as inhibition, at one concentration (the size of the read-out at that concentration, not a potency): 17%
Compound 4: middle estimate off by 33 percentage points, on the high side, and the stated range ends above it.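

In this assay, putting phenylsulfonyl in place of 3-chlorobenzyl on an aromatic nitrogen gives a number 26 percentage points lower from compound 3 to compound 4 (beyond the scatter), so the outcome seen on the core of compound 1 did not carry over to the core of compound 3: the same change on two cores in this assay, a number 10 percentage points higher (within the scatter) from compound 1 to compound 2 and a number 26 percentage points lower (beyond the scatter) from compound 3 to compound 4, 36 percentage points apart, beyond the scatter of two such steps In this small set, then, the result of this change depends on the core that carries it, and the step on one core would have been a poor guide to the step on the other. It does not show which part of the two cores makes the difference, since they are not broken down here, and two pairs at a single concentration cannot give a rule for the series or say anything about potency.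

The compounds shown leave open how other groups on the same aromatic nitrogen, such as an unsubstituted benzyl, a methylsulfonyl or a plain hydrogen, would read on each of the two cores. They also leave open whether the gap between the two steps would persist with a shorter or longer chain in place of the present one, or on a further core carrying a different amine.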